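A few compounds are considered here, and "the series" means these few. Any claim that something is new, unique, unknown or untested is made for them only; others in the source may bear on it.

In a functional assay on MDA-MB-231 cells (Homo sapiens) for inhibition, read by sulforhodamine B assay, with a stated time of 72 h (a lower number here means a stronger inhibitor of growth, a higher number a weaker inhibitor of growth), compound 1 (`CCOC(=O)/C=C/c1ccncc1-c1ccc2c(cnn2C)c1`) gives > 10000 nM, which is a limit of the assay and not a number. Compound 1 therefore stands at the limit of > 10000 nM in this assay, at which 1 of the 3 values shown sits. Two other compounds do return numbers: compound 2 (`CNC(=O)/C=C/c1ccncc1-c1ccc2cc[nH]c2c1`) gives 7680 nM, and compound 3 (`CCOC(=O)/C=C/c1ccncc1-c1ccc2ccccc2c1`) gives 8090 nM. These two values lie within the usual scatter of each other, although compound 2 carries a methylcarbamoyl group and compound 3 an ethoxycarbonyl group, each on a different core.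

Compound 4 (`CNC(=O)/C=C/c1ccncc1-c1ccc2c(cnn2C)c1`) keeps the core of compound 1 and changes one group: methylamino in place of ethoxy on a carbonyl carbon. Within the data shown here, no measured pair isolates this swap, so its size can only be judged loosely. The closeness of compound 2 at 7680 nM and compound 3 at 8090 nM points to a small step, probably none beyond the scatter, and if anything toward a slightly lower number. The expected step is an at least 1.2-fold lower number from compound 1 to compound 4 (0.09 log units; that floor lies within the scatter). Compound 4 is estimated at 8000 nM, with an expected range from 3500 nM to 15000 nM.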

Compound 4, concentration for 50% growth inhibition: > 10000 nM
Compound 4: no number, only a limit (the forecaster's own chance of this, stated with the estimate: 45%); middle value at least 1.2-fold (0.09 log units) away from the limit.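

In this assay compound 4 gives > 10000 nM, which is a limit of the assay and not a number. No step can be read between compound 1 and compound 4, since both stop at a limit: the limit of > 10000 nM in this assay, at which 2 of the 4 values shown sit.

As far as these compounds go, whether methylamino in place of ethoxy on a carbonyl carbon changes growth inhibition at all, and by how much, stays open.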